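Opening a Ring: From Compound 2 to Compound 4

This account rests on a few compounds, and the source may have more. Where it says the series, first, only, none or still open, it means among the compounds named here.

Measured so far:
Compound 1 `CCCCCCCCCCc1ccc(-c2noc(CC3CNC3)n2)cc1` gives 63% in an assay on HeLa cells for inhibition of sphingosine-1-phosphate transporter SPNS2 (Mus musculus), read by LC-MS, tested at 2 uM; a lower number here means less inhibition, a higher number more inhibition at the concentration tested (going by the name of the read-out).
Compound 2 `CCCCCCCCCCc1ccc(-c2noc([C@@H]3CCCN3)n2)cc1` gives 21%.
Compound 3 `CCCCCCCCCCc1ccc(-c2noc([C@@H](N)CCCCN)n2)cc1` gives 43%.

Compound 2 stands lowest of the three. The step of a number 42 percentage points lower from compound 1 to compound 2 (beyond the scatter) was large, and a number 22 percentage points higher from compound 2 to compound 3 (beyond the scatter) was modest. Compound 4 `CCCCCCCCCCc1ccc(-c2noc(CC(O)CNCC)n2)cc1` is not yet measured; it differs from compound 2 by 3-(ethylamino)-2-hydroxypropyl in place of pyrrolidin-2-yl on an aromatic carbon. The nearest guide is compound 3, where a ring was likewise exchanged for an open chain carrying nitrogen, and the number rose. The change to compound 4 brings a similar open chain, so a modest rise is expected, about a number 21 percentage points higher from compound 2 to compound 4 (beyond the scatter). Compound 4 is therefore estimated at 42%, in a range from 24% to 62%.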

Compound 4, a percentage reported as inhibition, at one concentration (the size of the read-out at that concentration, not a potency): 5%
Compound 4: the middle estimate sits 37 percentage points above what was measured, and the stated range ends above it.
By their numbers in this assay, from the lowest: compound 4; then compound 2; then compound 3; then compound 1.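

In this assay, an open chain at this position does not by itself raise the number: 3-(ethylamino)-2-hydroxypropyl in place of pyrrolidin-2-yl lowers it (a number 16 percentage points lower from compound 2 to compound 4 (beyond the scatter)), the opposite of what 1,5-diaminopentyl did. The two open chains are far apart (a number 38 percentage points lower from compound 3 to compound 4 (beyond the scatter)), so what the chain carries matters, not merely the absence of a ring. For the compounds shown here, compound 4 is the lowest of the four, and the largest step is the one from the azetidine compound (a number 58 percentage points lower from compound 1 to compound 4 (beyond the scatter)).

Nothing shown here gives a reason for these differences. As far as these compounds go, what the same chain would give without its hydroxyl, or with a methyl in place of the ethyl on its nitrogen, remains open.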